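Swapping the Amide Arm on the Shared Core

The compounds below may be only part of what the source reports. "The series", "measured", "known", "first", "only" and "open" are said of these compounds alone.

Measured so far:
compound 1 `COc1ncc(-c2ccc3nc(NC(C)=O)nn3c2)cc1NS(=O)(=O)c1ccc(Cl)cc1`: 2090 nM
compound 2 `COc1ncc(-c2ccc3nc(NC(=O)C4CC4)nn3c2)cc1NS(=O)(=O)c1ccc(F)cc1`: 4850 nM
compound 3 `O=C(Nc1nc2ccc(-c3cnc(Cl)c(NS(=O)(=O)c4ccc(F)cc4)c3)cn2n1)C1CC1`: 11000 nM

Of the compounds shown here, three built on one shared core have been tested in a functional assay on U-87MG ATCC cells (Homo sapiens) for antiproliferative activity, read by MTT assay, with a stated time of 48 h; on this read-out higher numbers stand for weaker inhibition and lower numbers for stronger inhibition. Compound 2 stands second highest of the three numbers. Among the measured compounds shown here, the only single-change step among them is a 2.3-fold higher number from compound 2 to compound 3 (0.36 log units; beyond the scatter), a modest move to a weaker result. Compound 1 differs from compound 2 in two places at once, so its value can only be read as a whole: compound 1 gives 2090 nM, the lowest of the three.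

Compound 4 `CNC(=O)CNc1nc2ccc(-c3cnc(OC)c(NS(=O)(=O)c4ccc(F)cc4)c3)cn2n1` differs from compound 2 by (methylcarbamoyl)methyl in place of cyclopropylcarbonyl on a nitrogen on an aromatic ring. For the measured compounds named here, no measured step touches this part of the molecule; the one step on record changes a group on an aromatic carbon elsewhere, and compound 1 offers no clean comparison. The change at hand trades a ring-bearing carbonyl group for a chain that brings one hydrogen-bond donor, and the measured data give no guide to its effect. With nothing to lean on, the expected step of a 1.0-fold higher number from compound 2 to compound 4 (0.01 log units; within the scatter) is kept small and stated with wide uncertainty. Compound 4 is therefore estimated at 5000 nM, with a range from 1500 nM to 16000 nM.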

Compound 4, half-maximal inhibitory concentration: 7290 nM
Compound 4: the middle estimate sits 1.5-fold (0.16 log units) below what was measured; the measured number falls inside the stated range.
By their numbers in this assay, from the lowest: compound 1; then compounds 2, 4 and 3 (each within the scatter of the next, the first and the last beyond it).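

Among the compounds shown here, replacing cyclopropylcarbonyl with (methylcarbamoyl)methyl on a nitrogen on an aromatic ring gives, in this assay, a 1.5-fold higher number from compound 2 to compound 4 (0.18 log units; within the scatter), the first measured step at this part of the molecule. The earlier step concerned only chloro in place of methoxy on an aromatic carbon, whereas this one shows that a group with no ring and one hydrogen-bond donor can stand in for a group with a three-membered ring and no donor, both with 5 heavy atoms, without the number leaving the usual scatter of repeated measurements. For this one pair, then, the exchange leaves no change that can be told apart from that scatter, and nothing measured here offers an explanation of the result.

The compounds shown leave open how a free amine, a carboxylic acid or a longer chain would behave on this same nitrogen, so two groups give only a narrow view of the position. They also leave open whether the same exchange would give a similar result on compound 3, which carries chloro in place of methoxy.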